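The source may hold more compounds than are shown below. What is called first, only, known or untested is meant among the compounds shown, and "the series" means these compounds.

For the measured compounds named here, compound 2 `O[C@@H]1[C@H](O)[C@@H]2C[C@@H]2[C@H]1n1cnc2c(NCc3cc(F)ccc3F)nc(Cl)nc21` gives 16.5 nM in an assay on CHO cells for displacement of a labelled ligand from adenosine receptor A3 (Homo sapiens), with a stated time of 60 min (on this read-out higher numbers stand for weaker inhibition and lower numbers for stronger inhibition), the lower of the two numbers measured so far; compound 1 `O[C@@H]1[C@H](O)[C@@H]2C[C@@H]2[C@H]1n1cnc2c(NCc3ccccc3F)nc(Cl)nc21` gives 41.5 nM. Going by the values given here, the only measured step, a 2.5-fold lower number from compound 1 to compound 2 (0.40 log units; beyond the scatter), came from fluoro in place of hydrogen on an aromatic carbon. Compound 3 `COc1ccc(F)c(F)c1CNc1nc(Cl)nc2c1ncn2[C@H]1[C@H](O)[C@H](O)[C@@H]2C[C@@H]21` differs from compound 2 by 2,3-difluoro-6-methoxyphenyl in place of 2,5-difluorophenyl on a saturated chain carbon bound to a nitrogen on an aromatic ring. Among the compounds with values here, this swaps one difluoro pattern for another and adds a methoxy group, which the single measured step covers only loosely, so a step of a 1.2-fold higher number from compound 2 to compound 3 (0.08 log units; within the scatter) in this assay is expected, staying within the scatter. Compound 3 is therefore estimated at 20 nM, with a range of 6 nM to 70 nM.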

Compound 3, inhibition constant: 83.2 nM
Beside the measured number, compound 3's estimate is 4.2-fold (0.62 log units) below it; the whole stated range lies below it.
By their numbers in this assay, from the lowest: compound 2; then compounds 1 and 3 (each within the scatter of the next).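

For the compounds shown here, the one earlier step on this ring lowered the number, but a different pattern of groups on the same ring can go the other way: in this assay the change gives a 5.0-fold higher number from compound 2 to compound 3 (0.70 log units; beyond the scatter) on the read-out. Against the 2-fluorophenyl group, the new ring gives a 2.0-fold higher number from compound 1 to compound 3 (0.30 log units; within the scatter) so the advantage of compound 2 is not kept. Nothing available explains this result.

The compounds shown leave open how much of the step belongs to the methoxy group and how much to the changed fluorine pattern. From the compounds shown here alone, how a ring carrying an amine or a carboxylic acid would read also remains open.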